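Trimming one methoxy from the most cytotoxic chalcone analogue

A few compounds are considered here, and "the series" means these few. Any claim that something is new, unique, unknown or untested is made for them only; others in the source may bear on it.

Among the three measured compounds, compound 3 `COc1ccc(C(=O)/C=C/c2cc(-c3cc(OC)c(OC)c(OC)c3)n[nH]2)cc1OC` stands lowest: in a functional assay on PC-3 cells (Homo sapiens) for cytotoxicity, read by sulforhodamine B assay, with a stated time of 48 h, tested at 10 uM (on this read-out higher numbers stand for a weaker effect at the one concentration tested and lower numbers for a stronger effect), compound 3 gives -88%. Compound 1 `COc1cc(-c2cc(/C=C/C(=O)c3ccc(N)cc3)[nH]n2)cc(OC)c1OC` gives 1% and compound 2 `COc1cc(-c2cc(/C=C/C(=O)c3ccc(Cl)c(Cl)c3)[nH]n2)cc(OC)c1OC` gives 39%, so the aryl group on the carbonyl carbon moves the number widely, as shown by a number 89 percentage points lower from compound 1 to compound 3 (beyond the scatter) and a number 127 percentage points lower from compound 2 to compound 3 (beyond the scatter). Compound 4 `COc1ccc(C(=O)/C=C/c2cc(-c3cc(OC)c(OC)c(OC)c3)n[nH]2)cc1` differs from compound 3 by hydrogen in place of methoxy on an aromatic carbon. Going by the values given here, no measured step removes a methoxy from this ring, so the direction is uncertain; the large swings seen for other changes on that ring suggest the loss is unlikely to be neutral. Compound 4 is expected to give -45%, between -95% and 15%, a step of a number 43 percentage points higher from compound 3 to compound 4 (beyond the scatter) that is estimated to weaken the effect somewhat.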

Compound 4, a percentage reported as activity, at one concentration (the size of the read-out at that concentration, not a potency): -68%
Compound 4: middle estimate off by 23 percentage points, on the high side; the measured number falls inside the stated range.
By their numbers in this assay, from the lowest: compound 3; then compound 4; then compound 1; then compound 2.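

In this assay, going from 3,4-dimethoxyphenyl to 4-methoxyphenyl gives a number 20 percentage points higher from compound 3 to compound 4 (beyond the scatter) and so costs only a modest part of the effect, far less than the choice of aryl group as a whole. That wider choice shows in a number 107 percentage points lower from compound 2 to compound 4 (beyond the scatter) and in a number 69 percentage points lower from compound 1 to compound 4 (beyond the scatter) and thus stays large with the single methoxy. Nothing available explains the size of the step at this position. From the compounds shown here alone, whether a hydroxy or an ethoxy in this place would match the methoxy stays open, as does what a phenyl without any methoxy would give.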